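Trimming the amide: from piperazine to dimethylamine

The compounds below may be only part of what the source reports. "The series", "measured", "known", "first", "only" and "open" are said of these compounds alone.

Of the compounds shown here, three sharing one core have been measured so far. Compound 1 `N#CC1(NC(=O)[C@@H]2C[C@@H](S(=O)(=O)c3ccccc3)C[C@H]2C(=O)N2CC3CCC(C2)O3)CC1` gives 1 nM in an assay on isolated protein for inhibition of cathepsin S (Homo sapiens), read by fluorescence, with a stated time of 20 min; a higher number here means a weaker inhibitor, a lower number a stronger inhibitor. Compound 2 `CC1CCN(C(=O)[C@@H]2C[C@H](S(=O)(=O)c3ccccc3)C[C@H]2C(=O)NC2(C#N)CC2)CC1` gives 0.5 nM in this assay, and compound 3 `N#CC1(NC(=O)[C@@H]2C[C@@H](S(=O)(=O)c3ccccc3)C[C@H]2C(=O)N2CCNCC2)CC1` gives 11 nM. Compound 3 thus stands with the highest number of the three: one measured step is an 11-fold higher number from compound 1 to compound 3 (1.04 log units; beyond the scatter), and the other is a 22-fold higher number from compound 2 to compound 3 (1.34 log units; beyond the scatter), both beyond the scatter and both arising from what sits on the carbonyl carbon.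

Compound 4 `CN(C)C(=O)[C@@H]1C[C@H](S(=O)(=O)c2ccccc2)C[C@H]1C(=O)NC1(C#N)CC1` has not yet been measured. It differs from compound 3 in one place: dimethylamino in place of piperazin-1-yl on a carbonyl carbon, so that a (piperazin-1-yl)carbonyl becomes a dimethylcarbamoyl. The two measured steps that bear on this position both show that replacing the piperazin-1-yl group by a ring without a hydrogen-bond donor lowers the number by a large margin, as in a 22-fold higher number from compound 2 to compound 3 (1.34 log units; beyond the scatter) read in reverse. Dimethylamino carries no donor either, but it is also no ring, so the account from compound 3 to compound 4 is expected to be a lowering of moderate size, a 2.8-fold lower number from compound 3 to compound 4 (0.44 log units; beyond the scatter), rather than the full drop seen for compound 2. For compound 4 the estimate in this assay is 4 nM, within a range from 1.2 nM to 13 nM.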

Compound 4, half-maximal inhibitory concentration: 6 nM
For compound 4 the middle estimate is 1.5-fold (0.18 log units) below the measured one; the range from low to high includes it.
By their numbers in this assay, from the lowest: compounds 2 and 1 (each within the scatter of the next); then compounds 4 and 3 (each within the scatter of the next).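

On this carbonyl carbon, dimethylamino and piperazin-1-yl cannot be told apart in this assay (in the step of a 1.8-fold lower number from compound 3 to compound 4 (0.26 log units; within the scatter)), so here the loss of the ring and of the hydrogen-bond donor and acceptor of piperazin-1-yl leaves no change beyond the scatter. Having no hydrogen-bond donor is therefore not enough on its own to reach the low numbers of the two larger groups: dimethylamino also has none, yet stands well apart from 4-methylpiperidin-1-yl (in the step of a 12-fold higher number from compound 2 to compound 4 (1.08 log units; beyond the scatter)) and from the bridged group of compound 1 (in the step of a 6.0-fold higher number from compound 1 to compound 4 (0.78 log units; beyond the scatter)), and only these two groups, both with rings and more carbon atoms, give the low numbers so far. Nothing measured here explains why these groups differ at this position.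

The compounds leave open where, going from dimethylamino towards 4-methylpiperidin-1-yl, the low numbers begin, which a diethylamino, a pyrrolidin-1-yl or an unsubstituted piperidin-1-yl on the same carbonyl carbon would help to place. They also leave open whether a morpholin-4-yl, with a ring oxygen in place of the second ring nitrogen of piperazin-1-yl, would fall with compound 3 or with compound 1.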